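A few compounds are considered here, and "the series" means these few. Any claim that something is new, unique, unknown or untested is made for them only; others in the source may bear on it.

Measured so far in an assay on HEK293 cells for agonist activity at transient receptor potential cation channel subfamily M member 8 (Homo sapiens), read by fluorescence and calcium flux, with a stated time of 15 min; a lower number here means that less compound is needed, a higher number that more compound is needed for the effect:
compound 1 `Cc1ccc(OCC(=O)N(Cc2cccs2)C(C)C)cc1` gives 70 nM
compound 2 `Cc1ccc(OCC(=O)N(Cc2cccs2)c2ccncc2)cc1` gives 52 nM
compound 3 `Cc1ccc(OCC(=O)N(Cc2cccs2)c2ccccc2)cc1` gives 23 nM

Compound 3 stands lowest of the three in this assay; the steps of a 2.3-fold lower number from compound 2 to compound 3 (0.35 log units; beyond the scatter) and a 3.0-fold lower number from compound 1 to compound 3 (0.48 log units; beyond the scatter) both lie beyond the scatter, whereas a 1.3-fold lower number from compound 1 to compound 2 (0.13 log units; within the scatter) does not. Compound 4 `COCCN(Cc1cccs1)C(=O)COc1ccc(C)cc1` differs from compound 3 by 2-methoxyethyl in place of phenyl on an amide-type nitrogen. The step that bears most on this change is a 3.0-fold lower number from compound 1 to compound 3 (0.48 log units; beyond the scatter), where a saturated group on this nitrogen gave way to phenyl and the number fell. Compound 4 goes the opposite way, from phenyl back to a chain, so the number is expected to rise by a modest step, a 2.6-fold higher number from compound 3 to compound 4 (0.42 log units; beyond the scatter). Compound 4 is estimated at 60 nM in this assay, with a range from 25 nM to 150 nM.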

Compound 4, half-maximal effective concentration: 400 nM
For compound 4 the middle estimate is 6.7-fold (0.82 log units) below the measured one; measured number outside the range, above it.
By their numbers in this assay, from the lowest: compound 3; then compounds 2 and 1 (each within the scatter of the next); then compound 4.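

On the amide-type nitrogen in this assay, 2-methoxyethyl stands apart from all three earlier groups: the change is large in a 17-fold higher number from compound 3 to compound 4 (1.24 log units; beyond the scatter), and modest but beyond the scatter both in a 7.7-fold higher number from compound 2 to compound 4 (0.89 log units; beyond the scatter) and in a 5.7-fold higher number from compound 1 to compound 4 (0.76 log units; beyond the scatter). Among the compounds shown here, that last step shows that the non-aromatic groups at this nitrogen do not all give similar numbers, which the earlier compounds alone could not show. Nothing available here explains the gap. On these data alone, whether a plain butyl chain, or an amine in place of the ether oxygen, would lie nearer compound 1 or compound 4 stays open.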